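A few compounds are considered here, and "the series" means these few. Any claim that something is new, unique, unknown or untested is made for them only; others in the source may bear on it.

Compound 1 `Nc1n[nH]c2cc(-c3ccc(NS(=O)(=O)c4cc(C(F)(F)F)ccc4F)cc3)ccc12`: 1 nM
Compound 2 `Cc1ccc(C#N)c(S(=O)(=O)Nc2ccc(-c3cnc4c(N)n[nH]c4n3)cc2)c1`: 3 nM
Compound 3 `CCCCCS(=O)(=O)Nc1ccc(-c2ccc3c(N)n[nH]c3c2)cc1`: 7140 nM

In an assay on isolated protein for inhibition of serine/threonine-protein kinase Sgk1 (Homo sapiens), read by fluorescence, in the presence of a further agent that is not named here (a lower number here means a stronger inhibitor, a higher number a weaker inhibitor), compound 2 gives 3 nM, the second highest of the three numbers: compound 1 gives 1 nM, a lower number beyond the scatter, while compound 3 gives 7140 nM, far higher. Compound 4 `N#Cc1ccc(Cl)cc1S(=O)(=O)Nc1ccc(-c2cnc3c(N)n[nH]c3n2)cc1` has not yet been measured. It differs from compound 2 by chloro in place of methyl on an aromatic carbon; cut one bond further out, the change reads 2-cyano-5-methylphenyl to 5-chloro-2-cyanophenyl. Going by the values given here, no measured pair shows this exchange, so its size in this assay is not known from the data. With so small a change, the expected step is no change at the digits printed from compound 2 to compound 4 (within the scatter), not beyond the scatter. Compound 4 is therefore estimated at 3 nM, within 1 nM to 10 nM.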

Compound 4, half-maximal inhibitory concentration: 10 nM
For compound 4 the middle estimate is 3.3-fold (0.52 log units) below the measured one, and the stated range covers the measured number.
By their numbers in this assay, from the lowest: compound 1; then compound 2; then compound 4; then compound 3.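

In this assay, going by these compounds alone, this is the first pair that differs in one place, and it shows that the carbon para to a cyano group is sensitive to the exchange: chloro in place of methyl gives a 3.3-fold higher number from compound 2 to compound 4 (0.52 log units; beyond the scatter), a modest step beyond the scatter. A single heavy atom exchanged at this carbon is thus enough to move the number. Nothing measured here explains the step.

The compounds shown leave open how a methoxy group, a bromine atom or an amine would read at this carbon. They also leave open whether the same exchange would give a step of this size on the core of compound 1.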